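This account rests on a few compounds, and the source may have more. Where it says the series, first, only, none or still open, it means among the compounds named here.

In a functional assay, with a stated time of 6 min (a lower number here means a stronger inhibitor, a higher number a weaker inhibitor), compound 1 `S=c1[nH]nc(-c2ccc3c(c2)OCCO3)o1` gives 10600 nM and compound 2 `Fc1cccc(NCn2nc(-c3ccc4c(c3)OCCO4)oc2=S)c1` gives 6620 nM while compound 3 `FC(F)(F)c1cccc(NCn2nc(-c3ccc4c(c3)OCCO4)oc2=S)c1` gives 7620 nM in the same assay. All three values lie within the scatter of one another, so compound 2 stands level with the other two. Compared with compound 2, compound 4 `S=c1oc(-c2ccc3c(c2)OCCO3)nn1CNc1ccc(Cl)cc1` carries 4-chlorophenyl in place of 3-fluorophenyl on an amine nitrogen, a change counted as 4-chlorophenyl in place of 3-fluorophenyl on an amine nitrogen and not yet measured. Among the compounds with values here, the one measured step bearing on this is a 1.2-fold higher number from compound 2 to compound 3 (0.06 log units; within the scatter) with trifluoromethyl in place of fluoro on an aromatic carbon, and it stays within the scatter. Within the data shown here, no measured compound carries 4-chlorophenyl, so that single step is the only guide. A step of a 1.1-fold higher number from compound 2 to compound 4 (0.02 log units; within the scatter) is therefore expected, none beyond the scatter. Compound 4 is estimated at 7000 nM with an expected range of 3500 nM to 13000 nM in this assay once it is measured.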

Compound 4, half-maximal inhibitory concentration: 7270 nM
Beside the measured number, compound 4's estimate is 1.0-fold (0.02 log units) below it; the measured number falls inside the stated range.
By their numbers in this assay, from the lowest: compounds 2, 4, 3 and 1 (each within the scatter of the next).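

Placing 4-chlorophenyl in place of 3-fluorophenyl on an amine nitrogen in this assay gives a 1.1-fold higher number from compound 2 to compound 4 (0.04 log units; within the scatter). Exchanging the whole aryl group at this place thus leaves the number within the scatter, just as the smaller exchange on an aromatic carbon did with a 1.2-fold higher number from compound 2 to compound 3 (0.06 log units; within the scatter). Nothing available accounts for this flat result.

Still open, as far as these compounds go, is whether a different group on this nitrogen, such as a pyridine ring, a carboxylic acid or a plain alkyl chain, would move the number beyond the scatter. Also open, from the compounds shown here alone, is what a longer chain in place of the saturated chain carbon would do.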